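Thiocarbamate series: pyridyl swap at the amide-type nitrogen

The compounds below may be only part of what the source reports. "The series", "measured", "known", "first", "only" and "open" are said of these compounds alone.

Working notes on the series. Compound 1 `Nc1ccccc1NC(=O)c1ccc(CSC(=S)N2CCN(c3cccnc3)CC2)cc1` and compound 2 `CN(C(=S)SCc1ccc(C(=O)Nc2ccccc2N)cc1)c1cccnc1` share a core and were both run in a functional assay on A-375 cells (Homo sapiens) for antiproliferative activity, read by CCK-8 assay, with a stated time of 72 h, tested at 2 uM; on this read-out lower numbers stand for a weaker effect and higher numbers for a stronger effect at the one concentration tested. In this assay compound 1 gives 40.5%, and compound 2 gives 26.5%. Compound 2 thus stands lowest of the two numbers, with compound 1 higher by a margin beyond the scatter of repeated runs. Compound 3 `CN(Cc1ccncc1)C(=S)SCc1ccc(C(=O)Nc2ccccc2N)cc1` has not yet been measured in this assay. Compound 3 differs from compound 2 in one place: (pyridin-4-yl)methyl in place of pyridin-3-yl on an amide-type nitrogen The entering group sits on the amide-type nitrogen whose other neighbours are a saturated chain carbon and a thiocarbonyl carbon; cut one bond further out, the change reads methyl(pyridin-3-yl)amino to methyl((pyridin-4-yl)methyl)amino. For the measured compounds named here, no measured pair shows this change, so the two numbers available give no direction. The expected step is a number 3.5 percentage points higher from compound 2 to compound 3 (within the scatter), a size within the scatter. Compound 3 is estimated at 30%, in the range 15% to 50%.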

Compound 3, a percentage reported as inhibition, at one concentration (the size of the read-out at that concentration, not a potency): 31.4%
Compound 3: the middle estimate sits 1.4 percentage points below what was measured; the range from low to high includes it.
By their numbers in this assay, from the lowest: compounds 2, 3 and 1 (each within the scatter of the next, the first and the last beyond it).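

Read in this assay the exchange of pyridin-3-yl for (pyridin-4-yl)methyl on this amide-type nitrogen gives a number 4.9 percentage points higher from compound 2 to compound 3 (within the scatter) as the first step available at this position. On this read-out compound 2 and compound 3 cannot be told apart, so this one exchange gives no direction for the position. Nothing at hand bears on a cause for this result.

The exchange alters the ring attachment and adds a saturated carbon in the same step, and the compounds shown do not separate these two differences; (pyridin-3-yl)methyl or pyridin-4-yl on the same nitrogen would bear on that question. Also open, going by these compounds, is how this position responds to a group without a ring nitrogen, such as phenyl or benzyl, or to a longer chain such as 2-(pyridin-4-yl)ethyl.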